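Swapping the amine on compound 1 for a methylpiperazine

The source may report more compounds than this note shows. Statements on the series, on what has been measured and on what is new or still open speak of the compounds shown alone.

The measured compounds and their numbers in a functional assay on HCT-116 cells (Homo sapiens) for inhibition; a higher number here means a weaker inhibitor, a lower number a stronger inhibitor:
compound 1, `CCNC(=O)c1noc(-c2cc(C(C)C)c(O)cc2O)c1-c1cc(CNC(C)C)no1`, 109 nM
compound 2, `CCNC(=O)c1noc(-c2cc(C(C)C)c(O)cc2O)c1-c1cc(CNC(C)=O)no1`, 167 nM
compound 3, `CCCN(CCC)Cc1cc(-c2c(C(=O)NCC)noc2-c2cc(C(C)C)c(O)cc2O)on1`, 183 nM

Compound 1 has the lowest number of the three, but the gap to compound 2 is a 1.5-fold higher number from compound 1 to compound 2 (0.19 log units; within the scatter) and the gap to compound 3 is a 1.7-fold higher number from compound 1 to compound 3 (0.23 log units; within the scatter), so the three cannot be told apart in this assay. Compound 4, `CCNC(=O)c1noc(-c2cc(C(C)C)c(O)cc2O)c1-c1cc(CN2CCN(C)CC2)no1`, is not yet measured. It differs from compound 1 in one place: 4-methylpiperazin-1-yl in place of isopropylamino on a saturated chain carbon bound to an aromatic carbon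

Among the measured compounds shown here, two measured steps touch the same spot. From compound 1 to compound 3 the amine on that saturated chain carbon was changed and gave a 1.7-fold higher number from compound 1 to compound 3 (0.23 log units; within the scatter); from compound 2 to compound 3 a different exchange at the same carbon gave a 1.1-fold higher number from compound 2 to compound 3 (0.04 log units; within the scatter). Both stayed inside the scatter, which suggests this position tolerates changes of the group without moving the number much. The change to compound 4 is larger in what it brings in, a ring where the others had open chains, so the estimate leaves a little more room on the weaker side. The step from compound 1 to compound 4 is expected to be a 1.4-fold higher number from compound 1 to compound 4 (0.14 log units; within the scatter), not beyond the scatter. For compound 4 the estimate is 150 nM, with a range from 70 nM to 330 nM.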

Compound 4, half-maximal inhibitory concentration: 340 nM
The estimate for compound 4 lay 2.3-fold (0.36 log units) below the measured number; the whole stated range lies below it.
By their numbers in this assay, from the lowest: compounds 1, 2, 3 and 4 (each within the scatter of the next, the first and the last beyond it).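

Unlike the earlier steps at this saturated chain carbon, the exchange of isopropylamino for 4-methylpiperazin-1-yl in this assay gives a 3.1-fold higher number from compound 1 to compound 4 (0.49 log units; beyond the scatter) and so leaves the scatter, and the exchange of acetamido for the same ring gives a 2.0-fold higher number from compound 2 to compound 4 (0.31 log units; beyond the scatter) and also lies beyond it, which shows that this position does not accept every group equally, though both steps are modest. The open-chain dipropylamino group cannot be told apart from the ring, since a 1.9-fold higher number from compound 3 to compound 4 (0.27 log units; within the scatter) stays within the scatter, so compound 3 stands against any simple rule that separates rings from open chains here. No measurement at hand explains why the number differs between these groups.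

The compounds shown leave open whether the higher number of compound 4 goes with the six-membered ring itself or with its second nitrogen and the methyl group on it. A piperidine or a morpholine on the same carbon, or a piperazine with hydrogen in place of that methyl, would help to separate these readings.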